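A few compounds are considered here, and "the series" means these few. Any claim that something is new, unique, unknown or untested is made for them only; others in the source may bear on it.

For the measured compounds named here, in an ADME assay on microsomes from liver (Homo sapiens) for metabolic stability (on this read-out higher numbers stand for a longer-lived compound and lower numbers for a shorter-lived compound), compound 2 `CC#C[C@@H](Cc1nnn[nH]1)c1ccc(OCc2ccc3scc(C4CCCCC4)c3c2)cc1` gives 0.183 h, the lower of the two numbers measured so far. Compound 3 `CC#C[C@@H](Cc1nnn[nH]1)c1ccc(OCc2ccc3sc(F)c(-c4ccc(OCCOC)cc4C)c3c2)cc1` gives 1.95 h. Compound 1 `CC#C[C@@H](Cc1nnn[nH]1)c1ccc(OCc2ccc3scc(-c4cccnc4C)c3c2)cc1` has only a limit and not a number, < 0.0667 h. Compound 4 `CC#C[C@@H](Cc1nnn[nH]1)c1ccc(OCc2ccc3scc(-c4cncnc4C)c3c2)cc1` differs from compound 2 in one place: 4-methylpyrimidin-5-yl in place of cyclohexyl on an aromatic carbon. Here 4-methylpyrimidin-5-yl stands in place of cyclohexyl on an aromatic carbon, two ring bonds from the ring sulfur. Going by the values given here, the one measured step that bears on this is an at least 2.7-fold higher number from compound 1 to compound 2 (0.43 log units; beyond the scatter), with cyclohexyl in place of 2-methylpyridin-3-yl, and compound 4 brings a six-membered aromatic ring with a methyl group back to that carbon, so a step of like size in the opposite direction is expected. On these data alone, the size of that measured step stays open at one end, since it starts from the limit of < 0.0667 h in this assay, at which 1 of the 3 values shown sits. The estimated change is a 2.3-fold lower number from compound 2 to compound 4 (0.36 log units; beyond the scatter), towards a shorter half-life. Compound 4 is expected at 0.08 h, within an estimated range of 0.04 h to 0.25 h.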

Compound 4, half-life: 0.233 h
Estimate against measurement, compound 4: 2.9-fold (0.46 log units) below, within the range that was stated.
By their numbers in this assay, from the lowest: compounds 2 and 4 (each within the scatter of the next); then compound 3. At a limit, below all of these: compound 1.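

In this assay, cyclohexyl and 4-methylpyrimidin-5-yl on this aromatic carbon, two ring bonds from the ring sulfur, cannot be told apart: a 1.3-fold higher number from compound 2 to compound 4 (0.10 log units; within the scatter). The two aromatic groups can be told apart, with an at least 3.4-fold higher number from compound 1 to compound 4 (0.54 log units; beyond the scatter), so among the compounds shown, having an aromatic ring at this position does not by itself settle the half-life; which aromatic group stands there matters. Compound 1 has a limit and not a number, so the size of that step stays open at one end: the limit of < 0.0667 h in this assay, at which 1 of the 4 values shown sits.

On these data alone, it remains open whether a plain pyrimidin-5-yl without the methyl group, or a ring carrying an amine or a carboxylic acid, would read like compound 4 on this carbon. Compound 3 differs from compound 4 in more than one place, so no single group can account for the gap between their values.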